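The compounds below may be only part of what the source reports. "The series", "measured", "known", "first", "only" and "open" are said of these compounds alone.

Measured compounds:
Compound 1 `Cc1ccc(C(=O)Nc2cccc(-c3oc4cc(-c5ccc(F)cc5)ccc4c(=O)c3O)c2)cc1`: 6190 nM
Compound 2 `COc1cccc(C(=O)Nc2cccc(-c3oc4cc(-c5ccc(F)cc5)ccc4c(=O)c3O)c2)c1`: 5650 nM
Compound 3 `COc1cc(OC)cc(C(=O)Nc2cccc(-c3oc4cc(-c5ccc(F)cc5)ccc4c(=O)c3O)c2)c1`: 2700 nM

All three were tested in a functional assay on HeLa cells (Homo sapiens) for antiproliferative activity, read by CCK-8 assay, with a stated time of 72 h; a lower number here means a stronger inhibitor, a higher number a weaker inhibitor. Compound 3 gives the lowest number of the three, with compound 2 nearest at a 2.1-fold lower number from compound 2 to compound 3 (0.32 log units; beyond the scatter) and compound 1 furthest at a 2.3-fold lower number from compound 1 to compound 3 (0.36 log units; beyond the scatter). Compound 1 and compound 2 sit within the scatter of each other, as a 1.1-fold lower number from compound 1 to compound 2 (0.04 log units; within the scatter) shows.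

The next compound, compound 4 `CCCc1ccc(C(=O)Nc2cccc(-c3oc4cc(-c5ccc(F)cc5)ccc4c(=O)c3O)c2)cc1`, has not yet been measured in this assay. It differs from compound 3 in one place: 4-propylphenyl in place of 3,5-dimethoxyphenyl on a carbonyl carbon. Within the data shown here, the steps that bear on this change are the two that lead to compound 3, where a 4-methylphenyl or a 3-methoxyphenyl was replaced by the 3,5-dimethoxyphenyl, each a modest improvement. Compound 4 carries a 4-propylphenyl, which resembles the 4-methylphenyl of compound 1 more than the 3,5-dimethoxyphenyl of compound 3. The change from compound 3 to compound 4 is therefore expected to run in the opposite direction, as a modest rise in the number, estimated at a 2.0-fold higher number from compound 3 to compound 4 (0.31 log units; beyond the scatter). Compound 4 is accordingly expected to give about 5500 nM in this assay, with a likely range from 2500 nM to 12000 nM.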

Compound 4, half-maximal inhibitory concentration: 8790 nM
Beside the measured number, compound 4's estimate is 1.6-fold (0.20 log units) below it; low and high end bracket the measured number.
By their numbers in this assay, from the lowest: compound 3; then compounds 2, 1 and 4 (each within the scatter of the next).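

On this carbonyl carbon, a 3.3-fold higher number from compound 3 to compound 4 (0.51 log units; beyond the scatter) in this assay is the largest step seen so far, and it replaces a 3,5-dimethoxyphenyl carrying 2 hydrogen-bond acceptors with a 4-propylphenyl carrying none. The ethyl extension that turns the 4-methylphenyl into the 4-propylphenyl gives a 1.4-fold higher number from compound 1 to compound 4 (0.15 log units; within the scatter) and is not resolved in this assay, and the exchange of the 3-methoxyphenyl for the 4-propylphenyl, with a 1.6-fold higher number from compound 2 to compound 4 (0.19 log units; within the scatter) as its step, is likewise not resolved. Among the four compounds, only compound 3 now stands apart, since its steps to compounds 1, 2 and 4 are all beyond the scatter, while those three lie close together despite carrying different groups on the aromatic ring.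

No measurement shown here accounts for the separation of compound 3 from the other three. The compounds also leave open whether that separation depends on the two methoxy groups themselves, which a 3,5-dimethylphenyl or a 4-methoxyphenyl could test, and how a phenyl ring bearing an amine or a carboxylic acid would behave on this carbonyl carbon.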